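A Naphthalen-1-yl Group Replaces Methoxyphenyl: Expected Binding

The source may report more compounds than this note shows. Statements on the series, on what has been measured and on what is new or still open speak of the compounds shown alone.

Compound 2 `COc1cccc(N2CCN(CCCCCCN3C(=O)c4ccccc4S3(=O)=O)CC2)c1` carries a 3-methoxyphenyl group on an amine nitrogen in a ring of the shared core. In an ADME assay on HEK293 cells for displacement of a labelled ligand from 5-hydroxytryptamine receptor 6 (Homo sapiens), read by radioligand binding, with a stated time of 1 h (a higher number here means a weaker inhibitor, a lower number a stronger inhibitor), compound 2 gives 921 nM. Among the measured compounds shown here, of the two numbers measured so far this is the higher one, but only nominally: compound 1 `O=C1c2ccccc2S(=O)(=O)N1CCCCCCN1CCN(c2cccc(Cl)c2Cl)CC1`, which carries 2,3-dichlorophenyl at the same place, gives 920 nM in this assay, and the step of a 1.0-fold higher number from compound 1 to compound 2 (0.00 log units; within the scatter) lies within the scatter. Exchanging one aryl group for the other made no real difference here.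

Compound 3 `O=C1c2ccccc2S(=O)(=O)N1CCCCCCN1CCN(c2cccc3ccccc23)CC1` has not yet been measured. It differs from compound 2 in one place: naphthalen-1-yl in place of 3-methoxyphenyl on an amine nitrogen in a ring. For the measured compounds named here, the only measured step that bears on this change is a 1.0-fold higher number from compound 1 to compound 2 (0.00 log units; within the scatter), an aryl exchange at the same position that stayed within the scatter. No measurement speaks to a naphthalen-1-yl group itself. Compound 3 is therefore expected to stay close to compound 2, with the step of a 1.0-fold lower number from compound 2 to compound 3 (0.01 log units; within the scatter) expected to be small. Compound 3 is estimated at 900 nM in this assay, with a range from 300 nM to 2700 nM.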

Compound 3, inhibition constant: 157 nM
Estimate against measurement, compound 3: 5.7-fold (0.76 log units) above; the whole stated range lies above it.
By their numbers in this assay, from the lowest: compound 3; then compounds 1 and 2 (each within the scatter of the next).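

Earlier, the exchange at this position between two aryl groups gave a 1.0-fold higher number from compound 1 to compound 2 (0.00 log units; within the scatter), which might have suggested that the amine nitrogen in the ring tolerates different aryl groups with no effect on the number. Compound 3 shows that this position can respond: in this assay, naphthalen-1-yl gives a 5.9-fold lower number from compound 2 to compound 3 (0.77 log units; beyond the scatter) and a 5.9-fold lower number from compound 1 to compound 3 (0.77 log units; beyond the scatter), so among these three compounds, only the one carrying naphthalen-1-yl stands apart from the others. Nothing available here explains why this exchange lowers the number when the earlier one did not.

The compounds shown leave open whether the lower number depends on the second six-membered aromatic ring itself or on how the two-ring group is attached, a question that a naphthalen-2-yl group or a plain phenyl group at the same place would help to separate. They also leave open whether naphthalen-1-yl would give a similar step if a shorter chain replaced the one in the shared core.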